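A few compounds are considered here, and "the series" means these few. Any claim that something is new, unique, unknown or untested is made for them only; others in the source may bear on it.

Measured so far in a functional assay on A549 cells (Homo sapiens) for inhibition, read by MTT assay, with a stated time of 24 h; a lower number here means a stronger inhibitor, a higher number a weaker inhibitor:
- compound 1 `Cc1ccc(-c2cc(COC3(C(F)(F)F)Oc4ccccc4C=C3C(=O)O)on2)cc1`: 51200 nM
- compound 2 `CCOC(=O)C1=Cc2ccccc2OC1(OCc1cn(CC(=O)Nc2ccc(OC)cc2)nn1)C(F)(F)F`: 29400 nM
- compound 3 `O=C(O)C1=Cc2ccccc2OC1(OCc1cc(-c2ccc(F)cc2F)no1)C(F)(F)F`: a limit, > 150000 nM

Compound 2 stands lowest of the two numbers in this assay. Its nearest neighbour is compound 1, and that gap lies within the scatter, so no order between the two can be claimed. Compound 3 gives only a limit in this assay (the limit of > 150000 nM in this assay, at which 1 of the 3 values shown sits). Going by the values given here, the single measured step, an at least 2.9-fold higher number from compound 1 to compound 3 (0.46 log units; beyond the scatter), sits on an aromatic carbon of a different five-membered ring than the one changed here.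

Compound 4 `CCOC(=O)C1=Cc2ccccc2OC1(OCc1cn(-c2cccc(C(F)(F)F)c2)nn1)C(F)(F)F` is the next step. It differs from compound 2 by 3-(trifluoromethyl)phenyl in place of ((4-methoxyphenyl)carbamoyl)methyl on an aromatic nitrogen. Among the compounds with values here, no measured step touches the aromatic nitrogen of the three-nitrogen ring, and the swap of aryl groups from compound 1 to compound 3 concerns a different ring and a different point of attachment, so it bears on this step only loosely. The numbers for compound 1 and compound 2 show that the shared core with either of the two pendant arms gives weak inhibition in this assay.

With so little to lean on, the step from compound 2 to compound 4 is expected to be a 1.4-fold higher number from compound 2 to compound 4 (0.13 log units; within the scatter), in either direction. Compound 4 is therefore estimated at 40000 nM, with a range of 12000 nM to 130000 nM in this assay.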

Compound 4, half-maximal inhibitory concentration: > 150000 nM
Compound 4: only a limit was reported; the forecaster's own chance of this, stated with the estimate: 20%; middle value at least 3.7-fold (0.57 log units) away from the limit.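

In this assay, going by these compounds alone, exchanging ((4-methoxyphenyl)carbamoyl)methyl for 3-(trifluoromethyl)phenyl on the aromatic nitrogen gives an at least 5.1-fold higher number from compound 2 to compound 4 (0.70 log units; beyond the scatter), the first measured evidence that the group at this position affects the read-out, and it lies beyond the scatter. The group that leaves has 1 hydrogen-bond donor and 2 hydrogen-bond acceptors and the group that enters has 0 of each, but the whole arm changes in this one step, so the difference cannot be assigned to any single part of it. Compound 4 gives only a limit, which leaves the full size of the step unknown and places compound 4 at the same limit as compound 3: the limit of > 150000 nM in this assay, at which 2 of the 4 values shown sit.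

As far as these compounds go, it remains open whether the amide, the methylene link or the 4-methoxyphenyl ring of compound 2 accounts for the difference, a question that a simple benzyl group or an N-methyl amide on the same nitrogen would help to separate. Also open is how a carboxylic acid in place of the ethyl ester on the shared core would behave with the three-nitrogen ring arm, since no single-place comparison of that kind is shown.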